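Swapping a sulfonamide for a methyl amide on the ring

The source may report more compounds than this note shows. Statements on the series, on what has been measured and on what is new or still open speak of the compounds shown alone.

All three measured compounds share one core, carrying a bromine and a quinolinyl substituent, and differ only in the group on the amino side chain. Compound 1 `COCCNC(=O)CNc1ncc2c(Br)nn(-c3ccc4ncccc4c3)c2n1` carries an open-chain amide linker; in an assay on SK-OV-3 cells for inhibition of eIF-2-alpha kinase GCN2 (Homo sapiens) (on this read-out lower numbers stand for stronger inhibition and higher numbers for weaker inhibition), compound 1 gives "nd" (no result reported), so no number came back for it. Compound 2 `Brc1nn(-c2ccc3ncccc3c2)c2nc(N[C@@H]3CC[C@@H](c4ncc[nH]4)C3)ncc12` bears a five-membered carbon ring with a 1H-imidazol-2-yl group and in this assay compound 2 gives 545 nM. Compound 3 `COCCS(=O)(=O)N[C@@H]1CC[C@@H](Nc2ncc3c(Br)nn(-c4ccc5ncccc5c4)c3n2)C1` keeps that ring but carries a ((2-methoxyethyl)sulfonyl)amino group instead; in this assay compound 3 gives 262 nM, the lowest of the two reported numbers, the step being a 2.1-fold lower number from compound 2 to compound 3 (0.32 log units; beyond the scatter).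

Compound 4 `CNC(=O)[C@@H]1CC[C@@H](Nc2ncc3c(Br)nn(-c4ccc5ncccc5c4)c3n2)C1` is the next variation: methylcarbamoyl in place of ((2-methoxyethyl)sulfonyl)amino on a saturated ring carbon. Among the compounds with values here, the only measured step bearing on this position is the one from compound 2 to compound 3, which was modest, and it concerns a different pair of groups, so it guides only loosely. Both known substituents at this position gave numbers in the same general region, so compound 4 is expected to stay near compound 3, with the step from compound 3 to compound 4 estimated as a 1.3-fold higher number from compound 3 to compound 4 (0.13 log units; within the scatter). For compound 4 the estimate in this assay is 350 nM, with a plausible range from 120 nM to 1000 nM.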

Compound 4, half-maximal inhibitory concentration: 25 nM
Compound 4: the middle estimate sits 14-fold (1.15 log units) above what was measured, and the stated range ends above it.
By their numbers in this assay, from the lowest: compound 4; then compound 3; then compound 2.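

In this assay, this saturated ring carbon proves far more responsive than the earlier pair suggested: the first measured change there was modest, whereas methylcarbamoyl gives a 10-fold lower number from compound 3 to compound 4 (1.02 log units; beyond the scatter) and a 22-fold lower number from compound 2 to compound 4 (1.34 log units; beyond the scatter). Both steps lie beyond the scatter, making compound 4 the most potent of the three compounds with a reported number and showing that neither earlier group marked the best result available at this position among those shown. Methylcarbamoyl, with 4 heavy atoms against 8 in ((2-methoxyethyl)sulfonyl)amino, also shows that the larger of these two groups is not the one giving the lower number, and no measurement offered here explains the gain.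

The step from the sulfonyl-bearing group to the amide changes the linking atoms and the length of the side chain at once, so the compounds shown cannot separate those two changes. From the compounds shown here alone, it also remains open how far the result depends on the methyl group or the amide hydrogen, a question that a primary carboxamide, an ethylcarbamoyl, a dimethylcarbamoyl or a carboxylic acid on the same ring carbon would bear on.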